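This account rests on a few compounds, and the source may have more. Where it says the series, first, only, none or still open, it means among the compounds named here.

Measured so far in a functional assay on BXPC-3 cells (Homo sapiens) for inhibition, read by MTT assay, with a stated time of 7 days; a higher number here means a weaker inhibitor, a lower number a stronger inhibitor:

- compound 1 `CC(C)S(=O)(=O)c1ccc(S(=O)(=O)N2CCC[C@@H](C(=O)N3CCC(F)(F)CC3)C2)cc1`: 50 nM
- compound 2 `CCN(CC)C(=O)c1ccc(S(=O)(=O)N2CCC[C@@H](C(=O)N3CCC(F)(F)CC3)C2)cc1`: 240 nM

For the measured compounds named here, compound 2 has the higher of the two numbers in this assay; the only neighbour is compound 1, and the step between them, a 4.8-fold higher number from compound 1 to compound 2 (0.68 log units; beyond the scatter), is the single measured step in the set.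

Compound 3 `CN(C)S(=O)(=O)c1ccc(S(=O)(=O)N2CCC[C@@H](C(=O)N3CCC(F)(F)CC3)C2)cc1` differs from compound 2 in one place: dimethylsulfamoyl in place of diethylcarbamoyl on an aromatic carbon. Going by the values given here, the one measured step that bears on this change runs in the opposite sense, a sulfonyl-type group giving way to diethylcarbamoyl, and it raised the number, a 4.8-fold higher number from compound 1 to compound 2 (0.68 log units; beyond the scatter). Compound 3 reverses that direction, putting a sulfur-bearing group back where compound 1 also carries one, though dimethylsulfamoyl is not the same group as isopropylsulfonyl. The expectation is therefore a lower number than compound 2 in this assay, of roughly the size of the measured step but with room for the new group to fall short of compound 1.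

Compound 3 is estimated at 80 nM, with a range of 30 nM to 220 nM. The expected step is a 3.0-fold lower number from compound 2 to compound 3 (0.48 log units; beyond the scatter).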

Compound 3, half-maximal inhibitory concentration: 560 nM
For compound 3 the middle estimate is 7.0-fold (0.85 log units) below the measured one, outside the stated range (above it).
By their numbers in this assay, from the lowest: compound 1; then compound 2; then compound 3.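

In this assay, a sulfur-bearing group at this aromatic carbon does not in itself give a lower number: dimethylsulfamoyl in place of diethylcarbamoyl gives (a 2.3-fold higher number from compound 2 to compound 3 (0.37 log units; beyond the scatter)), the same direction as the step away from isopropylsulfonyl. The pair that keeps the sulfonyl group shows that the substituent on its sulfur carries much of the difference, since dimethylamino in place of isopropyl gives (an 11-fold higher number from compound 1 to compound 3 (1.05 log units; beyond the scatter)), a large step that places isopropylsulfonyl well ahead of dimethylsulfamoyl at this position. No measurement available here accounts for this order.

The compounds shown leave open whether the lower number of compound 1 depends on isopropyl specifically or extends to other carbon groups on the sulfonyl sulfur, such as methyl, ethyl or cyclopropyl. As far as these compounds go, it is also open whether a ring amine such as morpholine or pyrrolidine on the sulfonyl sulfur would follow dimethylamino, and whether the same amines on the carbonyl would follow diethylcarbamoyl.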